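Adding a Methyl to Compound 2: What to Expect

The source may report more compounds than this note shows. Statements on the series, on what has been measured and on what is new or still open speak of the compounds shown alone.

Measured so far:
compound 1 `Clc1cccc(NC2CCc3ccccc32)c1` gives 173 nM;
compound 2 `Clc1cccc(Nc2n[nH]c3ccccc23)c1` gives 84 nM;
compound 3 `Fc1cccc(Nc2n[nH]c3ccccc23)c1` gives 59 nM.

All three were tested in an assay for inhibition of acyl-CoA (8-3)-desaturase (Homo sapiens); a lower number here means a stronger inhibitor, a higher number a weaker inhibitor. Compound 2 stands second highest of the three numbers; compound 3 sits close to it, while compound 1 is the furthest away. For the measured compounds named here, the one measured step that differs in a single place, a 1.4-fold lower number from compound 2 to compound 3 (0.15 log units; within the scatter), swaps a halogen on the ring that carries the chloro group and changes little. Compound 4 `Cc1ccc2[nH]nc(Nc3cccc(Cl)c3)c2c1` differs from compound 2 in another way: methyl in place of hydrogen on an aromatic carbon. The methyl enters on an aromatic carbon of a six-membered aromatic ring of carbon only, part of a fused or bridged system of two rings. Going by the values given here, no measured step touches that ring, so nothing here shows how a small group there moves the number. The halogen swap from compound 2 to compound 3 suggests that small changes on the shared core are tolerated. Compound 4 is therefore expected to land near compound 2, with an estimated step of a 1.1-fold lower number from compound 2 to compound 4 (0.02 log units; within the scatter) that stays within the scatter, and an estimated value of 80 nM in a range from 30 nM to 220 nM.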

Compound 4, half-maximal inhibitory concentration: 6 nM
Beside the measured number, compound 4's estimate is 13-fold (1.12 log units) above it, and the stated range ends above it.
By their numbers in this assay, from the lowest: compound 4; then compounds 3 and 2 (each within the scatter of the next); then compound 1.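

In this assay, one methyl in place of hydrogen on an aromatic carbon gives a 14-fold lower number from compound 2 to compound 4 (1.15 log units; beyond the scatter), a large step from a single added carbon. For the compounds shown here, this position, on the six-membered aromatic ring of carbon only, is therefore far from neutral, whereas the only earlier step, on the ring that carries the chloro group, gave a 1.4-fold lower number from compound 2 to compound 3 (0.15 log units; within the scatter) and stayed within the scatter. No supporting measurement is available to explain why the methyl has so large an effect here.

The compounds shown leave open whether this step belongs to methyl alone, or whether an ethyl chain, a methoxy group or an amine on the same carbon would shift the number as much. They also leave open whether the same methyl would give a similar step on compound 3, which carries fluoro in place of chloro.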